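Swapping a Nitro Group for a Pentyl Chain

The source may hold more compounds than are shown below. What is called first, only, known or untested is meant among the compounds shown, and "the series" means these compounds.

Compound 2 `O=C1C2=C(C(=O)c3ncccc31)C1(CS2)NC(=O)N(c2ccc([N+](=O)[O-])cc2)C1=O` is the starting point of this comparison. In a functional assay on HT-29 cells (Homo sapiens) for antiproliferative activity, read by MTT assay, with a stated time of 96 h (on this read-out higher numbers stand for weaker inhibition and lower numbers for stronger inhibition), compound 2 gives 250 nM, the lowest of the two single numbers in this set. Compound 3 `O=C1NN(c2ccc([N+](=O)[O-])cc2)C(=O)C2(CSC3=C2C(=O)c2ncccc2C3=O)N1` gives 1010 nM, a clearly higher number than compound 2, which here means weaker inhibition. Among the measured compounds shown here, compound 1 `O=C1NC(=O)C2(CSC3=C2C(=O)c2ncccc2C3=O)N1` has been measured repeatedly, as the several entries of compound 1 in this assay, 190 nM; 180 nM; 190 nM (3 entries) shows, and gives 190 nM; 180 nM; 190 nM (3 entries); no computed step links it to compound 2, so the two values simply stand side by side.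

The new compound 4 `CCCCCc1ccc(N2C(=O)NC3(CSC4=C3C(=O)c3ncccc3C4=O)C2=O)cc1` differs from compound 2 in one place: pentyl in place of nitro on an aromatic carbon. The pentyl chain sits on an aromatic carbon of a six-membered aromatic ring of carbon only, para to a large group. For the measured compounds named here, no measured step of this kind exists among the compounds above, so the size of the change in this assay is uncertain; a modest shift toward weaker inhibition, or none beyond the scatter, seems most likely. Compound 4 is therefore expected to give about 400 nM, within a range from 120 nM to 1500 nM. The step of a 1.6-fold higher number from compound 2 to compound 4 (0.20 log units; within the scatter) is thus estimated to be a small weakening.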

Compound 4, half-maximal inhibitory concentration: 250 nM
The estimate for compound 4 lay 1.6-fold (0.20 log units) above the measured number, and the stated range covers the measured number.
By their numbers in this assay, from the lowest: compounds 2 and 4 (each within the scatter of the next); then compound 3.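

Pentyl in place of nitro on an aromatic carbon, para to a large group, brings no change at the digits printed from compound 2 to compound 4 (within the scatter) in this assay. Among the compounds shown here, until now, nitro was the only group seen on this ring, so the result shows that this position can carry a pentyl chain, which has no hydrogen-bond acceptors, and that nitro is not needed to keep this level of inhibition. Repeat measurements in this assay agree closely, as one compound illustrates: the several entries of compound 1 in this assay, 190 nM; 180 nM; 190 nM (3 entries)

As far as these compounds go, with only nitro and pentyl compared at this position, it remains open whether a smaller group such as an amine, a carboxylic acid, or a longer chain would fit as well. From the compounds shown here alone, the same swap on the ring of compound 3 is also open. These data do not explain the matching numbers of the two groups here.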